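From a Fixed Alkene to a Flexible Cyclobutyl Amide

The compounds below may be only part of what the source reports. "The series", "measured", "known", "first", "only" and "open" are said of these compounds alone.

Measured so far in a functional assay on KETR3 cells (Homo sapiens) for inhibition, read by MTT assay, with a stated time of 120 h; a higher number here means a weaker inhibitor, a lower number a stronger inhibitor:
Compound 1 `CNC(=O)C#Cc1ccc(NC(=O)Nc2ccc(Cl)c(C(F)(F)F)c2)cc1` gives 24700 nM.
Compound 2 `CNC(=O)/C(C)=C/c1ccc(NC(=O)Nc2ccc(Cl)c(C(F)(F)F)c2)cc1` reaches only a limit of the assay, > 50000 nM.
Compound 3 `CNC(=O)/C=C(\C)c1ccc(NC(=O)Nc2ccc(Cl)c(C(F)(F)F)c2)cc1` likewise reaches only a limit of the assay, > 50000 nM.

Compound 3 thus stands at the limit rather than at a number, a point underlined by the limit of > 50000 nM in this assay, at which 2 of the 3 values shown sit. The next compound, compound 4 `O=C(CCc1ccc(NC(=O)Nc2ccc(Cl)c(C(F)(F)F)c2)cc1)NC1CCC1`, carries 2-(cyclobutylcarbamoyl)ethyl in place of 1-methyl-2-(methylcarbamoyl)ethenyl on an aromatic carbon. The measured step that ends at compound 3 is an at least 2.0-fold higher number from compound 1 to compound 3 (0.30 log units; that floor lies within the scatter), while a step that the two limits leave unreadable from compound 2 to compound 3. Among the measured compounds shown here, all three values here are far from potent, and no measured step points to a gain. Compound 4 is therefore expected to remain weak, with an estimated step of an at least 1.6-fold lower number from compound 3 to compound 4 (0.22 log units; that floor lies within the scatter). The estimate for compound 4 is 30000 nM, expected to fall between 8000 nM and 100000 nM.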

Compound 4, half-maximal inhibitory concentration: > 50000 nM
Compound 4 ended at the assay's limit; the forecaster's own chance of this, stated with the estimate: 50%; at least 1.6-fold (0.22 log units) between middle value and limit.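

At this position, the 2-(cyclobutylcarbamoyl)ethyl group brings a four-membered ring onto the amide, and in this assay compound 4 gives > 50000 nM, which is a limit of the assay and not a number. Among the compounds shown here, the only readable step is an at least 2.0-fold higher number from compound 1 to compound 4 (0.30 log units; that floor lies within the scatter), while the steps joining compound 4 to compound 2 and compound 3 cannot be read. This change therefore yields no measurable value, and the series gathers further at one limit: the limit of > 50000 nM in this assay, at which 3 of the 4 values shown sit.

As far as these compounds go, how far compound 4 lies beyond its limit remains open. So does whether a carboxylic acid or an amine at the end of this chain would give a measurable value.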